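This account rests on a few compounds, and the source may have more. Where it says the series, first, only, none or still open, it means among the compounds named here.

Of the compounds shown here, three sharing one core have been measured in an assay on HEK293 cells for inhibition of Steryl-sulfatase (Homo sapiens), tested at 1 uM; a lower number here means a weaker effect, a higher number a stronger effect of the compound at the concentration tested. Compound 1, with the structure `CN(C)CCN(Cc1ccccc1)c1cccc(C(=O)N2CCc3ccc(OS(N)(=O)=O)cc3C2)c1`, gives 28.6% in this assay. Compound 2, `CN(CCN1CCCCC1)c1ccc(C(=O)N2CCc3ccc(OS(N)(=O)=O)cc3C2)cc1`, gives 26.8%, and compound 3, `NS(=O)(=O)Oc1ccc2c(c1)CN(C(=O)c1cccc(N3CCN(Cc4ccccc4)CC3)c1)CC2`, gives 23.7%. Compound 1 has the highest of these three numbers, but its nearest neighbour, compound 2, lies only a little lower and the furthest, compound 3, still lies within the usual scatter, so the three cannot be told apart in this assay with any confidence.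

The next compound, compound 4, has the structure `CCCN(Cc1ccccc1)c1cccc(C(=O)N2CCc3ccc(OS(N)(=O)=O)cc3C2)c1`. It differs from compound 1 in a single place: methyl in place of dimethylamino on a saturated chain carbon, two bonds along the chain from a nitrogen on an aromatic ring. Within the data shown here, no measured pair in this set differs in just one place, so there is no measured step of this kind to lean on. The expectation therefore rests only on the three numbers above, all of which sit in the same modest band, and on the fact that compound 4 keeps the shared core of compound 1 unchanged.

The step from compound 1 to compound 4 is expected to be a number 8.6 percentage points lower from compound 1 to compound 4 (within the scatter), a small decrease that may well stay inside the scatter. Compound 4 is expected to give about 20% in this assay, most likely between 5% and 38%.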

Compound 4, a percentage reported as inhibition, at one concentration (the size of the read-out at that concentration, not a potency): 67.4%
Compound 4: middle estimate off by 47.4 percentage points, on the low side, outside the stated range (above it).
By their numbers in this assay, from the lowest: compounds 3, 2 and 1 (each within the scatter of the next); then compound 4.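

This position on the chain clearly matters: in this assay, putting methyl in place of dimethylamino, which read one bond further out turns 2-(dimethylamino)ethyl into propyl, gives a step that is a number 38.8 percentage points higher from compound 1 to compound 4 (beyond the scatter). The dimethylamino group is therefore not needed for a strong read-out at the concentration tested, and a plain propyl chain, carrying no nitrogen at its end, does far better in this pair. No measurement shown here accounts for the size of this step, so the reason for it remains unknown.

The nitrogen and the chain size change together in this single pair, so their contributions stay unseparated; a butyl chain, a 2-methoxyethyl chain or a primary amine at the same chain end would help pull them apart. On these data alone, it also remains open whether the step holds when the benzyl group on the nitrogen attached to the aromatic ring gives way to a smaller group such as methyl, and a percentage at one concentration does not give the potency of either compound.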